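The compounds below may be only part of what the source reports. "The series", "measured", "known", "first", "only" and "open" are said of these compounds alone.

In a functional assay on HepG2 cells (Homo sapiens) for inhibition, read by MTT assay, with a stated time of 24 h (on this read-out higher numbers stand for weaker inhibition and lower numbers for stronger inhibition), compound 1 `Cc1ccc(C(=O)NCC(=O)N/N=C/c2ccccc2OCc2ccccc2Cl)cc1` gives 13400 nM. Compound 2 `Cc1ccc(C(=O)NCC(=O)N/N=C/c2ccccc2OCc2ccc(C#N)cc2)cc1` gives > 50000 nM, which is a limit and not a number. Compound 3 `CCN(CC)c1ccc(/C=N/NC(=O)CNC(=O)c2ccc(F)cc2)c(OCc2ccccc2Cl)c1` gives > 50000 nM, which is also a limit. From the compounds shown here alone, compound 2 stands at the limit of > 50000 nM in this assay, at which 2 of the 3 values shown sit, and its true value remains unknown.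

Compound 4 `COc1ccc(COc2ccccc2/C=N/NC(=O)CNC(=O)c2ccc(C)cc2)cc1` has not yet been measured. It keeps the rest of compound 2 and carries methoxy in place of cyano on an aromatic carbon, para to a large group, turning 4-cyanobenzyl into 4-methoxybenzyl: methoxy in place of cyano on an aromatic carbon.

Going by the values given here, one measured step bears on this part of the molecule: an at least 3.7-fold higher number from compound 1 to compound 2 (0.57 log units; beyond the scatter), with 4-cyanophenyl in place of 2-chlorophenyl. Among the compounds with values here, it shows that a change here can move the number, but it is only a minimum size, and no measured compound carries methoxy. Compound 1 at 13400 nM shows that a close relative can give a measured number. Compound 4 could equally stay at the limit.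

A modest move towards stronger inhibition is the expected outcome, with real uncertainty: an at least 1.6-fold lower number from compound 2 to compound 4 (0.22 log units; that floor lies within the scatter). For compound 4 the estimated value is 30000 nM, with an expected range from 12000 nM to 70000 nM.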

Compound 4, half-maximal inhibitory concentration: > 50000 nM
Compound 4 ended at the assay's limit (the forecaster's own chance of this, stated with the estimate: 45%); at least 1.6-fold (0.22 log units) between middle value and limit.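

In this assay compound 4 gives > 50000 nM, which is a limit of the assay and not a number. Placing 4-methoxyphenyl on the chain carbon in place of 2-chlorophenyl gives an at least 3.7-fold higher number from compound 1 to compound 4 (0.57 log units; beyond the scatter), so a second group on this aromatic carbon, after the cyano of compound 2, also fails to reach the measured number of compound 1, and the earlier step, an at least 3.7-fold higher number from compound 1 to compound 2 (0.57 log units; beyond the scatter), no longer rests on a single example. The step from compound 2 to compound 4 cannot be read, so cyano and methoxy cannot be ranked against each other, and the new result only adds to the values gathered at one point: the limit of > 50000 nM in this assay, at which 3 of the 4 values shown sit.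

From the compounds shown here alone, how far apart compound 2 and compound 4 really lie stays open, as does whether either comes anywhere near the limit or lies far beyond it. Also open, going by these compounds, is whether a measurable number would return with a plain benzyl group, or with chlorine, an amine or a carboxylic acid in place of the methoxy on that same aromatic carbon.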